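Two Azetidine Amides at the Limit, and a Spiro Analogue

The source may report more compounds than this note shows. Statements on the series, on what has been measured and on what is new or still open speak of the compounds shown alone.

Compound 1 `Cc1cccc(S(=O)(=O)N2CC(c3nc(-c4cccc(Cl)c4)no3)C2)c1`: in an assay on HEK293 cells for positive allosteric modulation of metabotropic glutamate receptor 5 (Homo sapiens), read by FLIPR (a higher number here means that more compound is needed for the effect, a lower number that less compound is needed), compound 1 reaches only the assay limit, > 10000 nM.
Compound 2 `O=C(C1CCCO1)N1CC(c2nc(-c3cccc(Cl)c3)no2)C1`: in this assay compound 2 likewise reaches only the assay limit, > 10000 nM.

Both measured compounds share the same core and differ only in the group on the ring nitrogen, and neither gives a number: each sits at the limit, as summarised by the limit of > 10000 nM in this assay, at which 2 of the 2 values shown sit. Compound 2 therefore stands at the edge of what this assay can report, with no value to rank it by.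

Compound 3 `O=C(C1CCC2(CCC2)CC1)N1CC(c2nc(-c3cccc(Cl)c3)no2)C1` is the next compound and has not been measured. It changes compound 2 in one place: a group of 9 heavy atoms (9 carbon; one four-membered non-aromatic ring of carbon only, one six-membered non-aromatic ring of carbon only) in place of a group of 5 heavy atoms (4 carbon, 1 oxygen; one five-membered non-aromatic ring with 1 hetero atom), on a carbonyl carbon. Going by the values given here, with no measured step on the shared core to lean on, the expected step from compound 2 to compound 3 is an at least 1.2-fold lower number from compound 2 to compound 3 (0.09 log units; that floor lies within the scatter), and its direction is uncertain. Compound 3 is estimated to give about 8000 nM, within a range from 2000 nM to 30000 nM.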

Compound 3, half-maximal effective concentration: 1100 nM
Beside the measured number, compound 3's estimate is 7.3-fold (0.86 log units) above it; the whole stated range lies above it.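

Going by these compounds alone, compound 3 is the first compound here to give a real number in this assay, which shows that the group on the carbonyl carbon can decide whether the shared core reads out at all. Replacing oxolan-2-yl, with its ring oxygen and one hydrogen-bond acceptor, by the all-carbon group holding a four-membered and a six-membered ring gives an at least 9.0-fold lower number from compound 2 to compound 3 (0.95 log units; beyond the scatter). That step is only a floor, because one end of it is a limit: the limit of > 10000 nM in this assay, at which 2 of the 3 values shown sit.

The oxygen leaves and the carbon count grows in the same change, so the compounds shown cannot tell which of the two matters. Going by these compounds, whether a plain cyclohexyl, a phenyl or a longer alkyl chain on the same carbonyl carbon would also give a real number remains open.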